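Changing the chain on the ring nitrogen: cytotoxicity outlook

The source may hold more compounds than are shown below. What is called first, only, known or untested is meant among the compounds shown, and "the series" means these compounds.

Compound 1 `CC(C)N(c1ccnc(Nc2ccc(C#N)cc2)n1)c1c(F)cc(-c2ccc(C#N)cc2)cc1F` gives 172000 nM in an ADME assay on MT4 cells (Homo sapiens) for cytotoxicity, read by MTT assay, with a stated time of 5 days; a lower number here means that less compound is tolerated, a higher number that more compound is tolerated.
Compound 2 `N#Cc1ccc(Nc2nccc(N(CCCCl)c3c(F)cc(-c4ccc(C#N)cc4)cc3F)n2)cc1` gives > 250000 nM in this assay, a limit of the assay rather than a number.

Compound 2 therefore stands at the top of the measured range, as one of the values sitting at the limit of > 250000 nM in this assay, at which 1 of the 2 values shown sits. Going by the values given here, the single measured step, an at least 1.4-fold higher number from compound 1 to compound 2 (0.16 log units; that floor lies within the scatter), reaches only a floor that lies within the scatter, so it gives no sign that changing this chain shifts cytotoxicity. Compound 3 `COCN(c1ccnc(Nc2ccc(C#N)cc2)n1)c1c(F)cc(-c2ccc(C#N)cc2)cc1F` carries the change (methoxy in place of 2-chloroethyl on a saturated chain carbon bound to a nitrogen on an aromatic ring). Among the compounds with values here, that step is about as small as the one from isopropyl to 3-chloropropyl, which showed nothing beyond scatter, so no step beyond the scatter is expected here either, only that compound 3 may return a number rather than a limit. The estimate for compound 3 is 200000 nM, ranging from 100000 nM to 300000 nM, which is expected to mean a step of an at least 1.2-fold lower number from compound 2 to compound 3 (0.09 log units; that floor lies within the scatter).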

Compound 3, half-maximal cytotoxic concentration: 238000 nM
For compound 3 the middle estimate is 1.2-fold (0.08 log units) below the measured one; the measured number falls inside the stated range.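

In this assay, going by these compounds alone, the step of a 1.4-fold higher number from compound 1 to compound 3 (0.14 log units; within the scatter) is the first at this position read between two real numbers rather than against a limit. Methoxymethyl brings a hydrogen-bond acceptor into the chain, yet compound 3 cannot be told apart from compound 1, which carries isopropyl. The other step, an at least 1.0-fold lower number from compound 2 to compound 3 (0.02 log units; that floor lies within the scatter), reaches only a floor, so it sets no order between 3-chloropropyl and methoxymethyl, and compound 2 remains a limit of the assay: the limit of > 250000 nM in this assay, at which 1 of the 3 values shown sits.

From the compounds shown here alone, whether an amine, a carboxylic acid or a much longer chain at this position would move the number beyond the scatter stays open. Going by these compounds, the actual number for compound 2 stays open too.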